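The compounds below may be only part of what the source reports. "The series", "measured", "known", "first", "only" and "open" are said of these compounds alone.

The measured compounds and their values in a functional assay on L1210 cells (Mus musculus) for inhibition (on this read-out higher numbers stand for weaker inhibition and lower numbers for stronger inhibition), are these. Compound 1, `O=c1ccn(COCCO)c(=O)[nH]1`, reaches only a limit of the assay, > 1000 ug/mL. Compound 2, `CC(=O)OCCOCn1cnc2c(Cl)nc(Cl)nc21`, gives a number, 412 ug/mL. Compound 3, `Nc1nc2c(nc(Cl)n2COCCO)c(=O)[nH]1`, likewise reaches only a limit, > 1000 ug/mL.

Compound 3 therefore stands at the limit of > 1000 ug/mL in this assay, at which 2 of the 3 values shown sit, together with compound 1, while compound 2 alone has a measured number. No step between two measured compounds that differ in a single place is available among these three, so nothing measured speaks directly to the effect of a small change on this core.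

Compound 4, `Nc1nc2c(nc(Br)n2COCCO)c(=O)[nH]1`, differs from compound 3 by a single change: bromo in place of chloro on an aromatic carbon. A halogen is replaced by a halogen of the same kind of position on the shared core, with no change in ring count, hydrogen-bond donors or acceptors, or charge.

The step from compound 3 to compound 4 is expected to be a number no higher from compound 3 to compound 4 (the limit leaves the size open), that is, nothing beyond the scatter of repeated measurements, and compound 4 is expected most likely to reach the same limit of the assay as compound 3. Compound 4 is estimated at 1000 ug/mL, within a range from 400 ug/mL to 3000 ug/mL.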

Compound 4, concentration for 50% inhibition: > 500 ug/mL
Compound 4: no number, only a limit (the forecaster's own chance of this, stated with the estimate: 85%); the middle value lies beyond the limit too.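

In this assay compound 3 gives only a limit, > 1000 ug/mL. Compound 4 likewise gives only a limit, > 500 ug/mL, and the step between these two compounds cannot be read. The compounds shown leave open whether bromo in place of chloro on this aromatic carbon changes inhibition at all.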